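A few compounds are considered here, and "the series" means these few. Any claim that something is new, unique, unknown or untested is made for them only; others in the source may bear on it.

Compound 1 `CC1(C)CCCC2=C1C[C@@H](C(=O)O)[C@H](c1ccccc1)C2`: in an assay on isolated protein for inhibition of Apoptosis regulator Bcl-2 (Homo sapiens), read by fluorescence polarization, with stated times of 5 min and 10 min (on this read-out higher numbers stand for weaker inhibition and lower numbers for stronger inhibition), compound 1 gives > 23000 nM, a limit of the assay.
Compound 2 `CC(C)=CCCC1=CC[C@@H](C(=O)N(C)C)[C@H](c2ccccc2)C1`: in this assay compound 2 gives > 23000 nM, likewise a limit of the assay.

Compound 2 therefore stands at the edge of what the assay reports, and nothing in the set sits anywhere else: both readings fall on (the limit of > 23000 nM in this assay, at which 2 of the 2 values shown sit). Among the compounds with values here, no step between measured compounds can be drawn from the numbers so far.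

Compound 3 `CC(C)=CCCC1=CC[C@@H](C(N)=O)[C@H](c2ccccc2)C1` is the next compound to be measured in this assay. It differs from compound 2 in a single place: amino in place of dimethylamino on a carbonyl carbon. Within the data shown here, with no measured step to lean on, and with compound 2 held at the limit, the step in this assay is expected to be a step that the limit leaves unreadable from compound 2 to compound 3, none beyond the scatter. Compound 3 is accordingly estimated at 30000 nM, within a range of 12000 nM to 100000 nM, and most likely to be reported again only as a limit.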

Compound 3, inhibition constant: > 23000 nM
Compound 3 was reported as a limit; the forecaster's own chance of this, stated with the estimate: 85%; the middle value is on the limit's open side.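

In this assay compound 3 gives > 23000 nM, a limit of the assay. No step can be read between compound 2 and compound 3, as every reading sits at the same edge: the limit of > 23000 nM in this assay, at which 3 of the 3 values shown sit.

The compounds shown leave open whether any change to the shared core gives a reading inside the range of this assay.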